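Ring-Attached Group Swap on a Cytotoxic Enone Ester Scaffold

A few compounds are considered here, and "the series" means these few. Any claim that something is new, unique, unknown or untested is made for them only; others in the source may bear on it.

Compound 1 `CCCCCCCC/C=C\CCCCCCCC(=O)OC[C@H]1O[C@H](CC2=CCCCC2)C=CC1=O` gives 80 nM
Compound 2 `CCCCC/C=C\C/C=C\C/C=C\C/C=C\CCCC(=O)OC[C@@H]1C=CC(=O)[C@@H](CC2=CCCCC2)O1` gives 35000 nM
Compound 3 `CCCCC/C=C\C/C=C\C/C=C\C/C=C\CCCC(=O)OC[C@@H]1C=CC(=O)[C@@H](C2CCCC=C2C)O1` gives 5000 nM

Of the compounds shown here, three have been measured in a functional assay on LFCl2A cells (Rattus norvegicus) for cytotoxicity; on this read-out higher numbers stand for weaker inhibition and lower numbers for stronger inhibition. Compound 1 gives the lowest number of the three; its nearest neighbour is compound 3, and compound 2 lies furthest from it. The difference between the core of compound 1 and the core of compound 2 is not broken down here.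

One structural change appears twice in this set. From compound 2 to compound 3 the change is 2-methylcyclohex-2-en-1-yl in place of (cyclohex-1-en-1-yl)methyl on a saturated ring carbon, and it produced a 7.0-fold lower number from compound 2 to compound 3 (0.85 log units; beyond the scatter). The same change, on the core of compound 1, leads to compound 4 `CCCCCCCC/C=C\CCCCCCCC(=O)OC[C@H]1O[C@H](C2CCCC=C2C)C=CC1=O`, where the difference is 2-methylcyclohex-2-en-1-yl in place of (cyclohex-1-en-1-yl)methyl on a saturated ring carbon. The two changes sit at the same place on the ring and are the same change.

Compound 4 has not yet been measured in this assay. Because the change gave a 7.0-fold lower number from compound 2 to compound 3 (0.85 log units; beyond the scatter) on the core of compound 2, compound 4 is expected to give a lower number than compound 1, with an estimated step of a 4.0-fold lower number from compound 1 to compound 4 (0.60 log units; beyond the scatter). The expected number for compound 4 is 20 nM, with a range from 5 nM to 80 nM, since the core of compound 1 is not the core of compound 2 and the step may not carry over at the same size.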

Compound 4, half-maximal inhibitory concentration: 50 nM
Beside the measured number, compound 4's estimate is 2.5-fold (0.40 log units) below it; low and high end bracket the measured number.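

In this assay, putting 2-methylcyclohex-2-en-1-yl in place of (cyclohex-1-en-1-yl)methyl on the core of compound 1 gives a 1.6-fold lower number from compound 1 to compound 4 (0.20 log units; within the scatter), so this pair cannot be told apart on this read-out. The change therefore did not carry over at the same size from one core to the other: the same change on two cores in this assay, a 7.0-fold lower number (0.85 log units; beyond the scatter) from compound 2 to compound 3 and a 1.6-fold lower number (0.20 log units; within the scatter) from compound 1 to compound 4, 4.4-fold (0.64 log units) apart, beyond the scatter of two such steps What this does not show is which difference between the two cores goes with the gap; that difference is not broken down here, and a single pair of steps gives no rule for how the change would behave on any further core.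

The compounds shown leave open how the ester chain and the rest of the core each contribute, since the chain of compound 1 is not seen on the core of compound 2, or the reverse, with all else held the same. Going by these compounds, both groups compared at this place are also all-carbon rings of the same atom count, so it remains open what a phenyl ring, a piperidine or a simple hydroxymethyl group on the same saturated ring carbon would give on either core.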